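The compounds below may be only part of what the source reports. "The series", "measured", "known", "first", "only" and "open" are said of these compounds alone.

Compound 1 `COc1cc(-c2cc(C(=O)O)c3ccccc3n2)ccc1OCC(=O)Nc1ccccc1F`: 0.9. Compound 2 `COc1cc(-c2cc(C(=O)O)c3ccccc3n2)ccc1OCC(=O)Nc1cccc(C(F)(F)F)c1`: 1.3.

Among the measured compounds shown here, in a physicochemical assay for lipophilicity, using the shake flask method, in phosphate buffer, measured as octanol-water partition, at pH 7.4 (on this read-out higher numbers stand for higher lipophilicity and lower numbers for lower lipophilicity), compound 2 stands highest of the two numbers, set apart from compound 1 by the only measured step, a number 0.40 log units higher from compound 1 to compound 2 (beyond the scatter). Compound 3 `COc1cc(-c2cc(C(=O)O)c3ccccc3n2)ccc1OCC(=O)NCc1ccco1` is not yet measured; it differs from compound 2 by (furan-2-yl)methyl in place of 3-(trifluoromethyl)phenyl on an amide-type nitrogen. That single step is the only one that bears on this change, as both alter the group on the amide-type nitrogen, but the present swap is the larger of the two. A downward move in this assay is expected, estimated as a number 1.30 log units lower from compound 2 to compound 3 (beyond the scatter). Compound 3 is therefore expected at 0, within a range of -0.6 to 0.6.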

Compound 3, distribution coefficient: -0.3
Beside the measured number, compound 3's estimate is 0.30 log units above it; low and high end bracket the measured number.
By their numbers in this assay, from the lowest: compound 3; then compound 1; then compound 2.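

In this assay, the group on the amide-type nitrogen proves able to move the read-out far more than the earlier modest step showed: (furan-2-yl)methyl gives a number 1.60 log units lower from compound 2 to compound 3 (beyond the scatter) and a number 1.20 log units lower from compound 1 to compound 3 (beyond the scatter), both large. Compound 3 lies lowest of the three, with both steps beyond the scatter. Nothing available explains this fall.

Going by these compounds, it remains open whether the fall goes with the five-membered ring with its oxygen or with the methyl link to the nitrogen. A benzyl group on that nitrogen would separate the two.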